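The source may report more compounds than this note shows. Statements on the series, on what has been measured and on what is new or still open speak of the compounds shown alone.

Compound 1 `COc1ccc(CNC(=O)/C(C#N)=C/c2ccco2)cc1`: 31000 nM. Compound 2 `COc1ccc(CNC(=O)/C(C#N)=C/c2cc(Br)co2)cc1`: > 100000 nM.

In a functional assay on SW480 cells (Homo sapiens) for inhibition, read by MTT assay, with a stated time of 72 h (on this read-out lower numbers stand for stronger inhibition of growth and higher numbers for weaker inhibition of growth), compound 1 gives 31000 nM. For compound 2 this assay reports a limit, > 100000 nM, so compound 2 stands only at the limit of > 100000 nM in this assay, at which 1 of the 2 values shown sits. Within the data shown here, the single measured step, an at least 3.2-fold higher number from compound 1 to compound 2 (0.50 log units; beyond the scatter), is therefore itself a bound. Compound 3 `COc1ccc(CNC(=O)/C(C#N)=C/c2ccc(C)cc2)cc1` differs from compound 2 by 4-methylphenyl in place of 4-bromofuran-2-yl on a double-bonded chain carbon bound to a double-bonded chain carbon; the whole group is exchanged, so the measured step bears on it only loosely. Compound 1 gives the only numeric anchor with 31000 nM. The step is expected as an at least 2.5-fold lower number from compound 2 to compound 3 (0.39 log units; beyond the scatter), a rough estimate. Compound 3 is expected at 40000 nM, range 10000 nM to 150000 nM.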

Compound 3, concentration for 50% growth inhibition: 34000 nM
For compound 3 the middle estimate is 1.2-fold (0.07 log units) above the measured one, and the stated range covers the measured number.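

In this assay, the shift from a five-membered to a six-membered aromatic ring at this place leaves the number unresolved: a 1.1-fold higher number from compound 1 to compound 3 (0.04 log units; within the scatter). The other exchange sets 4-bromofuran-2-yl apart from 4-methylphenyl: an at least 2.9-fold lower number from compound 2 to compound 3 (0.46 log units; beyond the scatter). Compound 2 is held at a limit, so this step is only a bound: the limit of > 100000 nM in this assay, at which 1 of the 3 values shown sits.

On these data alone, it remains open whether a carboxylic acid or an amine on the aromatic ring at this place would bring the number below that of compound 1. Whether bromo on a phenyl ring would also raise the number is open too.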